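A few compounds are considered here, and "the series" means these few. Any claim that something is new, unique, unknown or untested is made for them only; others in the source may bear on it.

Compound 1 `O=c1nc2ccccn2cc1Cc1ccc(F)cc1C(F)(F)F` gives 9870 nM
Compound 2 `O=c1nc2ccc(Cl)cn2cc1Cc1ccc(Oc2nc(Cl)c(Cl)cc2Cl)cc1` gives 96900 nM
Compound 3 `O=c1nc2ccc(Cl)cn2cc1Cc1ccc([N+](=O)[O-])cc1` gives > 1000000 nM (a limit)

In a functional assay on MCF7 cells (Homo sapiens) for cytotoxicity, read by MTT assay, with a stated time of 24 h (on this read-out higher numbers stand for weaker inhibition and lower numbers for stronger inhibition), compound 1 stands at the lower of the two numbers, and compound 2 lies beyond the scatter above it. The entry for compound 3 is a limit and not a number. Compound 4 `O=c1nc2ccccn2cc1Cc1ccc(F)cc1` has hydrogen in place of trifluoromethyl on an aromatic carbon of compound 1 (hydrogen in place of trifluoromethyl on an aromatic carbon). Among the measured compounds shown here, no measured pair isolates this change. With compound 1 at 9870 nM as the lowest number on hand, a move to a higher number is expected in this assay rather than a gain. The expected change is a 3.0-fold higher number from compound 1 to compound 4 (0.48 log units; beyond the scatter) and would lie beyond the scatter, though with wide uncertainty. Compound 4 is estimated at 30000 nM with an expected range from 7000 nM to 150000 nM on this read-out.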

Compound 4, half-maximal inhibitory concentration: 200000 nM
Compound 4: middle estimate off by 6.7-fold (0.82 log units), on the low side, and the stated range ends below it.
By their numbers in this assay, from the lowest: compound 1; then compound 2; then compound 4. At a limit, above all of these: compound 3.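

Hydrogen in place of trifluoromethyl on an aromatic carbon gives, in this assay, a 20-fold higher number from compound 1 to compound 4 (1.31 log units; beyond the scatter), so the trifluoromethyl at this place, ortho to a large group and meta to a fluoro group, accounts for much of the standing of compound 1. The earlier compounds shown here differ from each other in more than one place and could not isolate any single position. No data at hand bear on the cause of this step.

Going by these compounds, whether a smaller group at this place, such as chlorine, methyl or an amine, would keep the standing of compound 1 remains open. Also open, on these data alone, is whether the step carries over to a core bearing chlorine.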